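Azole exchange on the benzylic carbon of compound 2

The compounds below may be only part of what the source reports. "The series", "measured", "known", "first", "only" and "open" are said of these compounds alone.

Working notes on the series. For the measured compounds named here, compound 2 `COc1ncc(-c2ccc3nccc(-c4ccc(Cn5cncn5)cc4)c3c2)cc1NS(=O)(=O)c1ccc(F)cc1F` stands on the lowest of the two numbers measured so far: in a functional assay on A549 cells (Homo sapiens) for cytotoxicity, read by MTT assay, with a stated time of 72 h (on this read-out lower numbers stand for stronger inhibition and higher numbers for weaker inhibition), compound 2 gives 16 nM. Its nearest neighbour is compound 1 `CCN(CC)Cc1ccc(-c2ccnc3ccc(-c4cnc(OC)c(NS(=O)(=O)c5ccc(F)cc5F)c4)cc23)cc1`, which in this assay gives 22 nM; the step of a 1.4-fold lower number from compound 1 to compound 2 (0.14 log units; within the scatter) lies within the scatter, so the two compounds cannot be ordered.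

The next compound, compound 3 `COc1ncc(-c2ccc3nccc(-c4ccc(Cn5ccnc5)cc4)c3c2)cc1NS(=O)(=O)c1ccc(F)cc1F`, differs from compound 2 by 1H-imidazol-1-yl in place of 1H-1,2,4-triazol-1-yl on a saturated chain carbon bound to an aromatic carbon. Going by the values given here, the only measured step at this position is the one from compound 1 to compound 2, which exchanged an open-chain amine for a five-membered aromatic ring without a step beyond the scatter. Among the compounds with values here, the present change, from one five-membered aromatic ring to another, is smaller still, and no step points in either direction for it.

Compound 3 is therefore expected to give about 16 nM in this assay, within a range of 7 nM to 40 nM. The expected step from compound 2 to compound 3 is no change at the digits printed from compound 2 to compound 3 (within the scatter), nothing beyond the scatter.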

Compound 3, half-maximal inhibitory concentration: 30.8 nM
For compound 3 the middle estimate is 1.9-fold (0.28 log units) below the measured one, and the stated range covers the measured number.
By their numbers in this assay, from the lowest: compounds 2, 1 and 3 (each within the scatter of the next).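

On a saturated chain carbon bound to an aromatic carbon, the exchange of the two azoles in this assay gives a 1.9-fold higher number from compound 2 to compound 3 (0.28 log units; within the scatter) and so does not order the two rings. The comparison with the open-chain amine gives a 1.4-fold higher number from compound 1 to compound 3 (0.15 log units; within the scatter) and also stays inside the scatter, so diethylamino, 1H-1,2,4-triazol-1-yl and 1H-imidazol-1-yl now form a set of three groups at this position that this read-out does not separate. Nothing at hand bears on the size of either step.

Open, going by these compounds, is whether a group of another kind on the same carbon, such as a morpholine or a carboxylic acid, would leave this set. Also open is whether a longer chain carrying 1H-imidazol-1-yl would stay within the scatter of these compounds.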